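Replacing the 2,4,5-trichlorophenyl group in the series

A few compounds are considered here, and "the series" means these few. Any claim that something is new, unique, unknown or untested is made for them only; others in the source may bear on it.

In a functional assay on HCT-116 cells (Homo sapiens) for antiproliferative activity, read by MTT assay, with a stated time of 72 h (on this read-out higher numbers stand for weaker inhibition and lower numbers for stronger inhibition), compound 3 `NC1=NC2(CCOCC2)N(OCCCOc2cc(Cl)c(Cl)cc2Cl)C(N)=N1` gives 2750 nM, and compound 1 `COc1ccc(OCCCON2C(N)=NC(N)=NC23CCOCC3)cc1` gives 1500 nM. These two values stand together, with a 1.8-fold higher number from compound 1 to compound 3 (0.26 log units; within the scatter). Compound 2 `Cc1cc(C)cc(OCCCON2C(N)=NC(N)=NC23CCOCC3)c1` stands apart at 190 nM, and the large step of a 14-fold higher number from compound 2 to compound 3 (1.16 log units; beyond the scatter) places compound 3 well on the weaker side of it.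

The next change gives compound 4 `NC1=NC2(CCOCC2)N(OCCCOc2ccccc2Br)C(N)=N1`, with 2-bromophenyl in place of 2,4,5-trichlorophenyl on an oxygen on a saturated carbon. All three measured steps are replacements at this same place. Besides the two above, there is the modest step of a 7.9-fold lower number from compound 1 to compound 2 (0.90 log units; beyond the scatter). Their sizes show that a change here can do nothing measurable or can shift the number a long way, and no clear rule emerges from three compounds. Going by the values given here, none of the measured compounds carries bromine, so no step speaks directly to this group.

Compound 3 sits at the weak end of the measured span, so a move away from it seems more likely to lower the number than to raise it. A moderate step is expected in this assay, estimated as a 3.4-fold lower number from compound 3 to compound 4 (0.54 log units; beyond the scatter). For compound 4 the estimated value is 800 nM, with an expected range of 220 nM to 2800 nM.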

Compound 4, half-maximal inhibitory concentration: 30 nM
Compound 4: middle estimate off by 27-fold (1.43 log units), on the high side, and the stated range ends above it.
By their numbers in this assay, from the lowest: compound 4; then compound 2; then compounds 1 and 3 (each within the scatter of the next).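

At this place, on an oxygen on a saturated carbon, the low end of the series in this assay moves down, with a 6.3-fold lower number from compound 2 to compound 4 (0.80 log units; beyond the scatter), so the 3,5-dimethylphenyl group no longer marks how far a replacement here can reach. Halogen on the aromatic ring does not by itself set the number: the two steps of a 92-fold lower number from compound 3 to compound 4 (1.96 log units; beyond the scatter) and a 50-fold lower number from compound 1 to compound 4 (1.70 log units; beyond the scatter) are both large, so the 2-bromophenyl group stands far from the 2,4,5-trichlorophenyl group, while the chlorinated compound 3 and the methoxy-bearing compound 1 remain within the scatter of each other. No measured evidence bearing on the cause of these steps is available.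

Open, on these data alone, is whether the lower number of compound 4 goes with bromine itself or with a ring carrying a single substituent, and a 2-chlorophenyl group or a phenyl group without substituents would separate these two readings. All four compounds also share the same chain and the same core, so the compounds shown say nothing on how a longer chain, or an amine on the aromatic ring, would behave alongside the 2-bromophenyl group.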